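Pyrrolidinyl to Morpholinyl on Two Related Cores

The source may report more compounds than this note shows. Statements on the series, on what has been measured and on what is new or still open speak of the compounds shown alone.

Compound 1, `O=c1cc(CSC(=S)N2CCCC2)oc2cc(Cl)ccc12`, gives > 40000 nM in a functional assay on HEp-2 cells (Homo sapiens) for antiproliferative activity, read by MTT assay, with a stated time of 72 h (a higher number here means a weaker inhibitor, a lower number a stronger inhibitor), and this value is a limit of the assay rather than a number.
Compound 2, `O=c1cc(CSC(=S)N2CCOCC2)oc2cc(Cl)ccc12`, gives 20600 nM in this assay.
Compound 3, `O=c1c(Cl)c(CSC(=S)N2CCCC2)oc2ccccc12`, gives 600 nM in this assay.

Compounds 1 and 2 share one core and differ only in the ring attached to the thiocarbonyl carbon: morpholin-4-yl in place of pyrrolidin-1-yl on a thiocarbonyl carbon. The measured step is an at least 1.9-fold lower number from compound 1 to compound 2 (0.28 log units; that floor lies within the scatter). Since compound 1 sits at the limit of > 40000 nM in this assay, at which 1 of the 3 values shown sits, only a floor for this step is known, and that floor lies within the usual scatter, so the direction of the change is not settled by these two compounds.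

Compound 3 is built from the same atoms as compound 1 joined differently; the difference between the two cores is not broken down here. Of the two numerical values, compound 3 gives the lower one, and its gap from compound 2 is beyond the scatter.

Compound 4, `O=c1c(Cl)c(CSC(=S)N2CCOCC2)oc2ccccc12`, has not yet been measured. It carries the same change on the core of compound 3: morpholin-4-yl in place of pyrrolidin-1-yl on a thiocarbonyl carbon. The place is the same, a thiocarbonyl carbon whose other neighbour is sulfur, so this is the same change as between compounds 1 and 2.

In this assay compound 4 is expected to show a step of a 1.2-fold lower number from compound 3 to compound 4 (0.08 log units; within the scatter). This expectation rests on compound 1 and compound 2, whose step an at least 1.9-fold lower number from compound 1 to compound 2 (0.28 log units; that floor lies within the scatter) gives only a floor within the scatter, and on compound 3 with its value 600 nM as the starting point. Compound 4 is therefore estimated at 500 nM, with a likely range from 200 nM to 1500 nM.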

Compound 4, half-maximal inhibitory concentration: 9000 nM
Estimate against measurement, compound 4: 18-fold (1.26 log units) below, and the stated range ends below it.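

On the core of compound 3, morpholin-4-yl in place of pyrrolidin-1-yl on a thiocarbonyl carbon is a large step in this assay, with a 15-fold higher number from compound 3 to compound 4 (1.18 log units; beyond the scatter) for this change. Carried from one core to the other, the same change therefore does not give the same result, and the step seen on the first core is no guide to the step on the second: the same change on two cores in this assay, an at least 1.9-fold lower number (0.28 log units; that floor lies within the scatter) from compound 1 to compound 2 and a 15-fold higher number (1.18 log units; beyond the scatter) from compound 3 to compound 4, at least 29-fold (1.46 log units) apart, beyond the scatter of two such steps. On these data alone, compound 1 stands at a limit of the assay and not at a number, so the real size of the first step stays unknown, and these two pairs do not show why the cores respond differently or how a further core would respond: the limit of > 40000 nM in this assay, at which 1 of the 4 values shown sits.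

The compounds shown leave open whether the large step on the core of compound 3 follows from the larger ring or from the oxygen in it, and piperidin-1-yl, a six-membered ring without that oxygen, would help separate the two. They also leave open which feature of the two cores decides the outcome, since the cores differ only in how the same atoms are joined, and a matching pair with fluorine in place of chlorine, or with no halogen at all, would test the role of the chlorine.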